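The compounds below may be only part of what the source reports. "The series", "measured", "known", "first", "only" and "open" are said of these compounds alone.

Working notes on the series. Two compounds have numbers in an assay on COS-1 cells for displacement of a labelled ligand from sodium-dependent dopamine transporter (Homo sapiens); a lower number here means a stronger inhibitor, a higher number a weaker inhibitor. Compound 1 `COC(=O)C1=C(c2ccc(C(C)(C)C)cc2)CCC1` carries the smaller ring; in this assay compound 1 gives 302000 nM. Compound 2 `COC(=O)C1=C(c2ccc(C(C)(C)C)cc2)CCCC1` carries the larger ring; in this assay compound 2 gives 605000 nM. Compound 2 shows the highest of the two numbers, but its gap to compound 1 lies within the scatter, so the two cannot be ordered against each other. Both sit very far toward the weak end of the scale.

The next compound, compound 3 `COC(=O)C1=C(c2ccc(C(F)(F)F)cc2)CCCC1`, keeps the core of compound 2 and changes only the aromatic substituent: trifluoromethyl in place of tert-butyl on an aromatic carbon. For the measured compounds named here, no step between measured compounds touches this part of the molecule, so the series itself gives no guide to the direction; the only anchor is that compound 2 is very weak at 605000 nM. The step is expected to be small, no larger than the scatter, with no preferred direction. Compound 3 is therefore estimated at 450000 nM in this assay, in a range of 120000 nM to 2000000 nM, which amounts to an expected step of a 1.3-fold lower number from compound 2 to compound 3 (0.13 log units; within the scatter) from compound 2.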

Compound 3, inhibition constant: 590000 nM
For compound 3 the middle estimate is 1.3-fold (0.12 log units) below the measured one, within the range that was stated.
By their numbers in this assay, from the lowest: compounds 1, 3 and 2 (each within the scatter of the next).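

In this assay, for the compounds shown here, trifluoromethyl in place of tert-butyl on an aromatic carbon gives a 1.0-fold lower number from compound 2 to compound 3 (0.01 log units; within the scatter) and is the first step that touches this part of the molecule. On the core of compound 2, with the group para to a large group, these two substituents cannot be told apart, and both compounds remain far toward the weak end of the scale. Nothing shown here bears on why the exchange leaves the number without a readable difference.

From the compounds shown here alone, it remains open whether any group at this position can move the number beyond the scatter, and an amine, a carboxylic acid or a hydroxyl group in place of tert-butyl would put that to the test. Going by these compounds, it is also open whether trifluoromethyl in place of tert-butyl on the core of compound 1 would give a similarly unreadable step, which would show whether this result holds for the smaller ring as well.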